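The compounds below may be only part of what the source reports. "The series", "measured", "known", "first", "only" and "open" are said of these compounds alone.

Compound 1 `O=C(c1ccc(-c2nc(-c3ccccn3)no2)s1)C(F)(F)F`: 90 nM
Compound 2 `O=C(c1ccc(-c2nnc(-c3ccccc3)o2)s1)C(F)(F)F`: 420 nM

Among the measured compounds shown here, in an assay for inhibition of histone deacetylase 4 (Homo sapiens) (on this read-out lower numbers stand for stronger inhibition and higher numbers for weaker inhibition), compound 1 gives 90 nM, the lower of the two numbers measured so far; compound 2 gives 420 nM, a higher number, and the gap between the two lies beyond the usual scatter. Compound 3 `O=C(c1ccc(-c2nc(-c3ccc(Cl)cc3Cl)no2)s1)C(F)(F)F` has not yet been measured. It differs from compound 1 in one place: 2,4-dichlorophenyl in place of pyridin-2-yl on an aromatic carbon. For the measured compounds named here, no measured pair shows this change on its own, and compound 2 differs from compound 1 in more than one place, so its value is only a loose guide. The expected step is a 2.8-fold higher number from compound 1 to compound 3 (0.44 log units; beyond the scatter), a moderate weakening, somewhat beyond the scatter. Compound 3 is estimated at 250 nM, with a range from 60 nM to 1000 nM.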

Compound 3, half-maximal inhibitory concentration: 240 nM
Estimate against measurement, compound 3: 1.0-fold (0.02 log units) above, and the stated range covers the measured number.
By their numbers in this assay, from the lowest: compound 1; then compounds 3 and 2 (each within the scatter of the next).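

In this assay, replacing pyridin-2-yl with 2,4-dichlorophenyl gives a 2.7-fold higher number from compound 1 to compound 3 (0.43 log units; beyond the scatter), so this position, on an aromatic carbon between two ring nitrogen atoms, accepts a ring of carbon only with a modest change in the number. The swap removes the ring nitrogen and adds two chlorine atoms at once, so the step cannot be divided between those two differences. No measurement shown here accounts for the step.

Still open, from the compounds shown here alone, is how a phenyl ring with a single chlorine would compare, and whether an amine or a carboxylic acid on that ring would be accepted.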